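Leaving methoxy on the shared core

The compounds below may be only part of what the source reports. "The series", "measured", "known", "first", "only" and "open" are said of these compounds alone.

Values in a physicochemical assay for solubility, read by spectrophotometry, in phosphate buffer, with a stated time of 18 h, at pH 7.4; on this read-out lower numbers stand for lower solubility and higher numbers for higher solubility:
- compound 1 `CCc1ccc(-c2nc3c(c(C)nn3-c3ccccc3)c(-c3ccccc3Br)c2C#N)cc1`: 1500 nM
- compound 2 `CCc1ccc(-c2nc3c(c(C)nn3-c3ccccc3)c(-c3ccccc3S(C)(=O)=O)c2C#N)cc1`: 2200 nM
- compound 3 `CCc1ccc(-c2nc3c(c(C)nn3-c3ccccc3)c(-c3ccccc3OC)c2C#N)cc1`: 7800 nM

Of the three, compound 3 has the highest number at 7800 nM, and its gaps to both of the others lie beyond the scatter. The next change leads to compound 4 `CCc1ccc(-c2nc3c(c(C)nn3-c3ccccc3)c(-c3ccccc3C(=O)OC)c2C#N)cc1`, and it is methoxycarbonyl in place of methoxy on an aromatic carbon, ortho to a large group, so that 2-methoxyphenyl becomes 2-(methoxycarbonyl)phenyl.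

All three measured steps concern this same place. Putting methoxy in place of bromo gave a 5.2-fold higher number from compound 1 to compound 3 (0.72 log units; beyond the scatter), and putting methoxy in place of methylsulfonyl gave a 3.5-fold higher number from compound 2 to compound 3 (0.55 log units; beyond the scatter). Both steps are modest. Methylsulfonyl in place of bromo gave a 1.5-fold higher number from compound 1 to compound 2 (0.17 log units; within the scatter), which is within the scatter. For the measured compounds named here, no measured compound carries methoxycarbonyl, so the evidence is indirect. Going by the values given here, the only two compounds without methoxy are compound 1 at 1500 nM and compound 2 at 2200 nM, and both lie lower than compound 3. A modest fall in this assay is therefore expected on leaving methoxy, of about the size of those steps, though a smaller one would not surprise. The expected change is a 2.6-fold lower number from compound 3 to compound 4 (0.41 log units; beyond the scatter). For compound 4 the estimated value is 3000 nM, with an expected range of 1200 nM to 7500 nM.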

Compound 4, solubility: 17000 nM
Compound 4: the middle estimate sits 5.7-fold (0.75 log units) below what was measured; measured number outside the range, above it.
By their numbers in this assay, from the lowest: compounds 1 and 2 (each within the scatter of the next); then compound 3; then compound 4.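

In this assay methoxy turns out not to mark the top of this series at the aromatic carbon ortho to a large group: methoxycarbonyl in its place gives a 2.2-fold higher number from compound 3 to compound 4 (0.34 log units; beyond the scatter) and so shows that leaving methoxy does not have to bring the number down. Methoxycarbonyl also stands clear of the other two groups, with a 7.7-fold higher number from compound 2 to compound 4 (0.89 log units; beyond the scatter) on replacing methylsulfonyl and an 11-fold higher number from compound 1 to compound 4 (1.05 log units; beyond the scatter) on replacing bromo, the latter being the only large step among these compounds, so that bromo and methylsulfonyl now sit together at the low end, followed by methoxy and then methoxycarbonyl. Nothing available here accounts for this rise.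

The compounds shown leave open how a carboxylic acid or a primary amide on this same carbon would read in this assay and whether a longer chain such as ethoxycarbonyl would keep the higher number. They also leave open whether the step from methoxy to methoxycarbonyl carries over when the shared core is changed elsewhere.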